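Halogenated phenyl swap on the diaryl imidazolidinedione series

The compounds below may be only part of what the source reports. "The series", "measured", "known", "first", "only" and "open" are said of these compounds alone.

For the measured compounds named here, compound 2 `C=CCn1c(=O)/c(=C\c2ccccc2OC)[nH]c(=O)/c1=C\c1ccccc1OC` has the higher of the two numbers so far in a functional assay on MCF7 cells (Homo sapiens) for cytotoxicity, read by CCK-8 assay, with a stated time of 72 h; a lower number here means a stronger inhibitor, a higher number a weaker inhibitor: compound 2 gives 41100 nM, while compound 1 `C=CCn1c(=O)/c(=C\c2cccc(Cl)c2Cl)[nH]c(=O)/c1=C\c1ccccc1OC` gives 2100 nM. Going by the values given here, the only measured step, a 20-fold higher number from compound 1 to compound 2 (1.29 log units; beyond the scatter), ties a 2,3-dichlorophenyl group to the lower number. Compound 3 `C=CCn1c(=O)/c(=C\c2ccc(F)c(Br)c2)[nH]c(=O)/c1=C\c1ccccc1OC` differs from compound 2 by 3-bromo-4-fluorophenyl in place of 2-methoxyphenyl on a double-bonded chain carbon bound to an aromatic carbon, reintroducing a halogenated phenyl at the same place. Among the compounds with values here, that single step is the only guide, so a move back toward the number of compound 1 is expected, estimated as a 9.1-fold lower number from compound 2 to compound 3 (0.96 log units; beyond the scatter). Compound 3 is therefore expected at about 4500 nM, within 1500 nM to 15000 nM.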

Compound 3, half-maximal inhibitory concentration: "not active" (no number reported)
No number was reported for compound 3, so the estimate cannot be set against anything.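

In this assay, for the compounds shown here, compound 3 is recorded as not active without a number, so no step from compound 2 to compound 3 can be read. The compounds shown leave open how 3-bromo-4-fluorophenyl ranks against the other two groups at this place. No evidence bears on this result.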